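The source may report more compounds than this note shows. Statements on the series, on what has been measured and on what is new or still open speak of the compounds shown alone.

Measured so far:
- Compound 1, `CC(C)Cc1ccc2c(NCCCNCc3ccco3)ccnc2c1`: in a physicochemical assay for solubility, with a stated time of 18 h, at pH 7.4 (a higher number here means a more soluble compound, a lower number a less soluble compound), compound 1 gives 4200 nM.
- Compound 2, `c1coc(CNCCCNc2ccnc3cc(CC4CCCCC4)ccc23)c1`: in this assay compound 2 gives 4200 nM.
- Compound 3, `COc1cccc(Oc2ccc3c(NCCCNCc4ccco4)ccnc3c2)c1`: in this assay compound 3 gives 14500 nM.

Compound 3 stands highest of these three numbers. The step of a 3.5-fold higher number from compound 1 to compound 3 (0.54 log units; beyond the scatter) and the step of a 3.5-fold higher number from compound 2 to compound 3 (0.54 log units; beyond the scatter) are both modest but lie beyond the scatter, while the step of no change at the digits printed from compound 1 to compound 2 (within the scatter) shows no change. So the two compounds without the 3-methoxyphenoxy group sit together, and compound 3 with it sits above them.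

Compound 4, `CCC(CC)c1ccc2c(NCCCNCc3ccco3)ccnc2c1`, has not yet been measured in this assay. Its difference from compound 3 is pentan-3-yl in place of 3-methoxyphenoxy on an aromatic carbon. The group that leaves is the one whose arrival raised the number in the steps of a 3.5-fold higher number from compound 1 to compound 3 (0.54 log units; beyond the scatter) and a 3.5-fold higher number from compound 2 to compound 3 (0.54 log units; beyond the scatter); the group that enters has no ring, which brings compound 4 closer in build to compound 1 and compound 2 than to compound 3. Within the data shown here, the expectation is therefore that the step of a 3.2-fold lower number from compound 3 to compound 4 (0.51 log units; beyond the scatter) runs the other way, undoing the gain seen in compound 3, because the step of a 3.5-fold higher number from compound 1 to compound 3 (0.54 log units; beyond the scatter) was the only kind of change that moved the number. Compound 4 is expected to give about 4500 nM, within a range from 2000 nM to 10000 nM.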

Compound 4, solubility: 4200 nM
Beside the measured number, compound 4's estimate is 1.1-fold (0.03 log units) above it; the measured number falls inside the stated range.
By their numbers in this assay, from the lowest: compounds 1, 2 and 4 (each within the scatter of the next); then compound 3.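

In this assay, replacing 3-methoxyphenoxy with pentan-3-yl on this aromatic carbon gives a 3.5-fold lower number from compound 3 to compound 4 (0.54 log units; beyond the scatter), so the higher number does not carry over to this open-chain group. The comparisons with the other two carbon-only groups read no change at the digits printed from compound 2 to compound 4 (within the scatter) and no change at the digits printed from compound 1 to compound 4 (within the scatter), which places a third such group alongside cyclohexylmethyl and isobutyl. Among these four compounds, a ring alone does not separate the groups, since cyclohexylmethyl has a ring yet compound 2 sits with compound 1 and compound 4, and only compound 3, with its aromatic ring and two oxygens in the group, stands apart.

Nothing shown here explains why the number changes with these groups. The compounds also leave open which part of 3-methoxyphenoxy goes with the higher number, the aromatic ring, the oxygen joining it to the core or the methoxy group, and a plain phenoxy, a benzyl group or a simple amine at this position would help to separate these parts.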